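Saturating the chain end of a diyne methyl ester

The source may hold more compounds than are shown below. What is called first, only, known or untested is meant among the compounds shown, and "the series" means these compounds.

The measured compounds in a functional assay on XF498 cells (Homo sapiens) for cytotoxicity (a higher number here means that more compound is needed for the effect, a lower number that less compound is needed), are:
compound 1, `CCCCCCCC#CC#CCO`, 5.59 ug/mL
compound 2, `CCCCCCCC#CC#CCOCC(=O)O`, 7.72 ug/mL
compound 3, `C=CCCCCCCCC#CC#CCOCC(=O)OC`, > 30 ug/mL

Compound 3 gives only a limit in this assay, (the limit of > 30 ug/mL in this assay, at which 1 of the 3 values shown sits), so no number is known for it. Compound 4, `CCCCCCCC#CC#CCOCC(=O)OC`, is to be measured in this assay. It differs from compound 3 in one place: hydrogen in place of vinyl on a saturated chain carbon, seven bonds along the chain from a triple-bonded carbon. With the vinyl gone, compound 4 carries the same saturated chain as compound 1 and compound 2, which both give numbers well under the limit of compound 3. Going by the values given here, the only measured step, a 1.4-fold higher number from compound 1 to compound 2 (0.14 log units; within the scatter), is a change at the oxygen end of the chain and says nothing about the chain end itself, so no measured step bears directly on this change. What can be drawn from the numbers is that the saturated chain of compound 1 and compound 2 sits in a range of ordinary activity, while compound 3 does not. Compound 4 is therefore expected to return from the limit to a number near those of compound 1 and compound 2, a step in this assay of an at least 3.0-fold lower number from compound 3 to compound 4 (0.47 log units; beyond the scatter). The estimate for compound 4 in this assay is 10 ug/mL, between 4 ug/mL and 30 ug/mL.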

Compound 4, concentration for half-maximal effect: > 30 ug/mL
Compound 4 was reported as a limit; the forecaster's own chance of this, stated with the estimate: 20%; middle value at least 3.0-fold (0.47 log units) away from the limit.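

Compound 3 and compound 4 both end as limits in this assay rather than as numbers, so the step between them cannot be read, and nothing shows that hydrogen in place of vinyl at this place changes the result: the limit of > 30 ug/mL in this assay, at which 2 of the 4 values shown sit.

What this adds is that the saturated chain alone does not keep the number low: methyl in place of hydrogen on an oxygen next to a carbonyl group gives an at least 3.8-fold higher number from compound 2 to compound 4 (0.58 log units; beyond the scatter), and the methyl ester set against the plain hydroxyl end gives an at least 5.3-fold higher number from compound 1 to compound 4 (0.72 log units; beyond the scatter). Compound 3 carries the same methyl ester, so among these four compounds, the two with that ester are the two at the limit, with or without the vinyl.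

On these data alone, how far past the limit each of these two esters lies stays unknown, so any effect of the vinyl remains hidden. As far as these compounds go, it is also open whether the loss belongs to the methyl ester alone or would also appear with an ethyl ester or an amide at that end of the molecule.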